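The source may hold more compounds than are shown below. What is called first, only, known or untested is meant among the compounds shown, and "the series" means these compounds.

Working notes on the series. In a functional assay on BaF3 cells (Mus musculus) for antiproliferative activity, read by CCK-8 assay and cell counting, with a stated time of 76 h (a higher number here means a weaker inhibitor, a lower number a stronger inhibitor), compound 1 (`COc1cc2nccc(Oc3ccc(Nc4nn(C)cc4C(=O)NC4CCCCC4)cc3)c2cc1C(N)=O`) gives 4800 nM and compound 2 (`COc1cc2nccc(Oc3ccc(Nc4nn(C)cc4C(=O)N4CCCC5CCCCC54)cc3)c2cc1C(N)=O`) gives 4330 nM in the same read-out. Among the compounds with values here, these two values lie within the scatter of each other, so compound 2 stands level with compound 1 and the numbers so far do not separate them.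

From compound 2 to compound 3 (`COc1cc2nccc(Oc3ccc(Nc4nn(C)cc4C(=O)NOCc4ccccc4)cc3)c2cc1C(N)=O`) the change is a group of 9 heavy atoms (7 carbon, 1 nitrogen, 1 oxygen; one six-membered aromatic ring of carbon only) in place of a group of 10 heavy atoms (9 carbon, 1 nitrogen; one six-membered non-aromatic ring of carbon only, one six-membered non-aromatic ring with 1 hetero atom), on a carbonyl carbon on a carbonyl carbon. Here (benzyloxy)amino enters, and its six-membered aromatic ring of carbon only takes the place of the two six-membered non-aromatic rings of the group that leaves. Neither compound 1 nor compound 2 carries such an aromatic ring, so the measured data offer only a thin guide.

Within the data shown here, with a 1.1-fold lower number from compound 1 to compound 2 (0.04 log units; within the scatter) as the only measured step on that carbonyl carbon, no step beyond the scatter is expected in this assay for compound 3, and no direction is favoured. The estimated change is a 1.1-fold lower number from compound 2 to compound 3 (0.03 log units; within the scatter) and it is no more than a placeholder for the absence of any expected shift. The expected value for compound 3 is 4000 nM with an estimated range from 1300 nM to 10000 nM in this read-out.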

Compound 3, half-maximal inhibitory concentration: > 10000 nM
Compound 3 was reported as a limit; the forecaster's own chance of this, stated with the estimate: 10%; at least 2.5-fold (0.39 log units) between middle value and limit.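

In this assay, compound 3 is reported only as a limit, not as a number: the limit of > 10000 nM in this assay, at which 1 of the 3 values shown sits.

Even so, the limit is enough to read both steps: the (benzyloxy)amino group gives an at least 2.3-fold higher number from compound 2 to compound 3 (0.36 log units; beyond the scatter), and benzyloxy in place of cyclohexyl on the amide-type nitrogen gives an at least 2.0-fold higher number from compound 1 to compound 3 (0.31 log units; beyond the scatter). Within the data shown here, the earlier pair showed only a 1.1-fold lower number from compound 1 to compound 2 (0.04 log units; within the scatter), so these are the first steps on this carbonyl carbon to lie beyond the scatter, and they show that the read-out at this place does respond to the group carried there, with both steps pointing to a weaker compound 3.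

From the compounds shown here alone, the true size of the shift stays open, since one end of both steps is a limit, and the three compounds cannot say whether it goes with the aromatic ring or with the oxygen of the benzyloxy group, as the entering group brings both together. A benzylamino group, which keeps the aromatic ring without that oxygen, and a cyclohexyloxyamino group, which keeps the oxygen without the aromatic ring, would separate the two.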